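Back from a phenylethenyl to an aryl substituent

A few compounds are considered here, and "the series" means these few. Any claim that something is new, unique, unknown or untested is made for them only; others in the source may bear on it.

The three measured compounds and their read-outs:
compound 1 `N#CC1=C(N)N(c2ccc(S(N)(=O)=O)cc2)C2=C(CCCC2)C1c1ccccc1O`, in a functional assay on Ehrlich cells (Mus musculus) for cytotoxicity, read by trypan blue exclusion, with a stated time of 2 h, tested at 100 ug/mL; a lower number here means a weaker effect, a higher number a stronger effect of the compound at the concentration tested: 100%
compound 2 `N#CC1=C(N)N(c2ccc(S(N)(=O)=O)cc2)C2=C(CCCC2)C1c1ccc(O)cc1`, in this assay: 100%
compound 3 `N#CC1=C(N)N(c2ccc(S(N)(=O)=O)cc2)C2=C(CCCC2)C1/C=C/c1ccccc1`, in this assay: 70%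

Compound 3 stands lowest of the three numbers in this assay. Its two neighbours lie together: the step of no change at the digits printed from compound 1 to compound 2 (within the scatter) is within the scatter, whereas a number 30 percentage points lower from compound 1 to compound 3 (beyond the scatter) and a number 30 percentage points lower from compound 2 to compound 3 (beyond the scatter) are both modest drops that lie beyond it.

The unmeasured compound 4 `COc1ccccc1C1C(C#N)=C(N)N(c2ccc(S(N)(=O)=O)cc2)C2=C1CCCC2` differs from compound 3 in one place: 2-methoxyphenyl in place of 2-phenylethenyl on a saturated ring carbon. Both measured steps that bear on this change, a number 30 percentage points lower from compound 1 to compound 3 (beyond the scatter) and a number 30 percentage points lower from compound 2 to compound 3 (beyond the scatter), replaced an aryl group on the saturated ring carbon with the 2-phenylethenyl group and lowered the number by a modest amount; the step to compound 4 runs the other way, putting an aryl group back in that place. Within the data shown here, no measured pair separates a hydroxyphenyl from a methoxyphenyl group, so the size of that distinction is unknown. Compound 4 is therefore expected to recover most of the modest loss, a step of a number 25 percentage points higher from compound 3 to compound 4 (beyond the scatter) in this assay. The estimate for compound 4 is 95%, within a range of 80% to 100%.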

Compound 4, a percentage reported as activity, at one concentration (the size of the read-out at that concentration, not a potency): 100%
The estimate for compound 4 lay 5 percentage points below the measured number; measured number inside the range.
By their numbers in this assay, from the lowest: compound 3; then compounds 1, 2 and 4 (each within the scatter of the next).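

In this assay, 2-methoxyphenyl in place of 2-phenylethenyl on the saturated ring carbon gives a number 30 percentage points higher from compound 3 to compound 4 (beyond the scatter), so the drop seen with 2-phenylethenyl does not extend to this aryl group, even though it has no hydroxyl hydrogen. Methyl in place of hydrogen on the oxygen gives no change at the digits printed from compound 1 to compound 4 (within the scatter), and moving from 4-hydroxyphenyl to 2-methoxyphenyl gives no change at the digits printed from compound 2 to compound 4 (within the scatter), so a free hydroxyl group is not needed for this read-out at the single concentration tested. That single concentration gives no ranking among the three aryl compounds.

From the compounds shown here alone, it remains open how an aryl group bearing an amine or a carboxylic acid, or a saturated propyl chain, would read at this carbon, and how compound 1, compound 2 and compound 4 would compare at lower concentrations. Nothing shown here gives a reason for these results.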